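The source may hold more compounds than are shown below. What is called first, only, known or untested is meant among the compounds shown, and "the series" means these compounds.

Measured so far:
compound 1, `COc1ccc(OC)c(Sc2ccc3nnc(-c4cccnc4)n3n2)c1`, 242 nM;
compound 2, `COc1ccc(OC)c(Sc2ccc3nnc(-c4ccncc4)n3n2)c1`, 349 nM;
compound 3, `COc1ccc(OC)c(Sc2ccc3nnc(-c4cnccn4)n3n2)c1`, 880 nM.

In an assay on isolated protein for inhibition of Leucine-rich repeat serine/threonine-protein kinase 2 (Homo sapiens), in the presence of a further agent that is not named here (on this read-out lower numbers stand for stronger inhibition and higher numbers for weaker inhibition), compound 2 stands second highest of the three numbers, with compound 1 nearest (a 1.4-fold higher number from compound 1 to compound 2 (0.16 log units; within the scatter)) and compound 3 furthest (a 2.5-fold higher number from compound 2 to compound 3 (0.40 log units; beyond the scatter)). Compound 4, `COc1ccc(OC)c(Sc2ccc3nnc(Cc4cnn(C)c4)n3n2)c1`, differs from compound 2 in one place: (1-methyl-1H-pyrazol-4-yl)methyl in place of pyridin-4-yl on an aromatic carbon. Within the data shown here, none of the measured steps covers this kind of change; all three swap one six-membered ring for another, giving a 1.4-fold higher number from compound 1 to compound 2 (0.16 log units; within the scatter), a 3.6-fold higher number from compound 1 to compound 3 (0.56 log units; beyond the scatter) and a 2.5-fold higher number from compound 2 to compound 3 (0.40 log units; beyond the scatter). Among the measured compounds shown here, those swaps moved the number by at most a modest amount, so a modest rise is the expectation here, with wide uncertainty because no measured step supports it directly. Compound 4 is therefore estimated at 800 nM (range 250 nM to 2500 nM), which means an expected step of a 2.3-fold higher number from compound 2 to compound 4 (0.36 log units; beyond the scatter) in this assay.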

Compound 4, half-maximal inhibitory concentration: 32000 nM
For compound 4 the middle estimate is 40-fold (1.60 log units) below the measured one; the whole stated range lies below it.
By their numbers in this assay, from the lowest: compounds 1 and 2 (each within the scatter of the next); then compound 3; then compound 4.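

Earlier swaps among six-membered rings at this position moved the number only modestly, whereas (1-methyl-1H-pyrazol-4-yl)methyl brings much larger rises against all three: a 92-fold higher number from compound 2 to compound 4 (1.96 log units; beyond the scatter), a 36-fold higher number from compound 3 to compound 4 (1.56 log units; beyond the scatter) and a 130-fold higher number from compound 1 to compound 4 (2.12 log units; beyond the scatter). The position is thus far from indifferent to what it carries. Nothing available explains this loss. The change replaces the ring and adds a linking carbon together, so which of the two accounts for the loss stays open. Also open, on these data alone, is how a directly attached 1-methyl-1H-pyrazol-4-yl or a pyridin-4-ylmethyl group would read.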